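Pyrazolyl chalcone series: aryl ketone swap in growth inhibition

The compounds below may be only part of what the source reports. "The series", "measured", "known", "first", "only" and "open" are said of these compounds alone.

Compound 1 `COc1ccc(C(=O)/C=C/c2cc(-c3cc(OC)c(OC)c(OC)c3)n[nH]2)cc1OC` gives 1340 nM in a functional assay on MDA-MB-435 cells (Homo sapiens) for inhibition, read by sulforhodamine B assay, with a stated time of 48 h; a lower number here means a stronger inhibitor of growth, a higher number a weaker inhibitor of growth. Compound 2 `COc1ccc(C(=O)/C=C/c2cc(-c3cc(OC)c(OC)c(OC)c3)n[nH]2)cc1`, which differs from it by hydrogen in place of methoxy on an aromatic carbon, gives 2200 nM in this assay; the step of a 1.6-fold higher number from compound 1 to compound 2 (0.22 log units; within the scatter) lies within the scatter. Of the two numbers seen so far, compound 2 shows the higher one, and its nearest neighbour is compound 1.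

Compound 3 `COc1cc(-c2cc(/C=C/C(=O)c3ccc(F)c(F)c3)[nH]n2)cc(OC)c1OC` is not yet measured. It differs from compound 2 by 3,4-difluorophenyl in place of 4-methoxyphenyl on a carbonyl carbon. Among the measured compounds shown here, the only measured step, from compound 1 to compound 2, concerns a change on the same ring but of a different kind, and it was within the scatter, so no measured step bears directly on this swap. The expected step in this assay, a 1.4-fold higher number from compound 2 to compound 3 (0.13 log units; within the scatter), is therefore a modest one, not clearly beyond the scatter. Compound 3 is estimated at 3000 nM, with a range from 900 nM to 10000 nM.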

Compound 3, concentration for 50% growth inhibition: 2880 nM
The estimate for compound 3 lay 1.0-fold (0.02 log units) above the measured number; low and high end bracket the measured number.
By their numbers in this assay, from the lowest: compounds 1, 2 and 3 (each within the scatter of the next, the first and the last beyond it).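

On the carbonyl carbon, the aryl group can lose its oxygen atoms altogether: 3,4-difluorophenyl in place of 4-methoxyphenyl gives a 1.3-fold higher number from compound 2 to compound 3 (0.12 log units; within the scatter) in this assay, so compound 2 and compound 3 cannot be told apart here. Against the 3,4-dimethoxyphenyl group, the same 3,4-difluorophenyl group gives a 2.1-fold higher number from compound 1 to compound 3 (0.33 log units; beyond the scatter), the only modest step in the series that exceeds the scatter, so this aryl swap separates compounds where the single methoxy loss did not. No supporting data bear on why these groups differ in this way.

Still open, as far as these compounds go, is whether a phenyl carrying an amine or a carboxylic acid on this carbonyl carbon would move the number further than these aryl groups do. Whether the step from compound 1 to compound 3 would hold up on the repeat of a modest gap also remains unsettled.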